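Fluoro to Trifluoromethyl: Estimating Compound 3 from One Step

This account rests on a few compounds, and the source may have more. Where it says the series, first, only, none or still open, it means among the compounds named here.

Among the measured compounds shown here, in a functional assay on LNCaP cells (Homo sapiens) for antiproliferative activity, read by propidium iodide staining, with a stated time of 96 h (a higher number here means a weaker inhibitor, a lower number a stronger inhibitor), compound 2 (`CC(O)(CSc1ccc(F)cc1)C(=O)Nc1cccc(S(F)(F)(F)(F)F)c1`) gives 26900 nM, the higher of the two numbers measured so far, which makes it the weaker inhibitor of the pair. Compound 1 (`CC(O)(CSc1ccc(S(F)(F)(F)(F)F)cc1)C(=O)Nc1cccc(S(F)(F)(F)(F)F)c1`) gives 12700 nM. The next molecule, compound 3 (`CC(O)(CSc1ccc(C(F)(F)F)cc1)C(=O)Nc1cccc(S(F)(F)(F)(F)F)c1`), keeps the core of compound 2 and changes one group: trifluoromethyl in place of fluoro on an aromatic carbon. This puts trifluoromethyl in place of fluoro on an aromatic carbon, para to a large group.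

For the measured compounds named here, only one measured step bears on this change. Replacing a larger sulfur-and-fluorine group with fluoro on that carbon gave a 2.1-fold higher number from compound 1 to compound 2 (0.33 log units; beyond the scatter), a modest change. Trifluoromethyl holds more atoms than fluoro and fewer than that larger group, so compound 3 is expected to recover part of that difference in this assay. One step is thin evidence, so this is only a cautious expectation of a lower number. The estimated change is small, at a 1.7-fold lower number from compound 2 to compound 3 (0.23 log units; within the scatter). For compound 3 the expected value is 16000 nM, with an estimated range from 8000 nM to 32000 nM.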

Compound 3, half-maximal inhibitory concentration: 17500 nM
Compound 3: middle estimate off by 1.1-fold (0.04 log units), on the low side, within the range that was stated.
By their numbers in this assay, from the lowest: compounds 1, 3 and 2 (each within the scatter of the next, the first and the last beyond it).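

In this assay, trifluoromethyl on this aromatic carbon, para to a large group, cannot be told apart from fluoro, with a 1.5-fold lower number from compound 2 to compound 3 (0.19 log units; within the scatter), and it cannot be told apart from the group of 6 heavy atoms in compound 1 either, with a 1.4-fold higher number from compound 1 to compound 3 (0.14 log units; within the scatter). Among the compounds shown here, only compound 1 and compound 2 stand apart beyond the usual scatter, so these three compounds give no firm ranking by group size, and the whole span seen at this position so far remains modest. Nothing measured here offers a reason for these numbers.

Every group shown on this carbon carries fluorine, so it remains open how an amine, a carboxylic acid or a longer carbon chain would read there, and whether any group at this position can move the number by more than this modest span. As far as these compounds go, all three compounds also share the rest of the molecule, so it is unknown whether this nearly flat picture would hold if the core of compound 2 were changed elsewhere.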